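This account rests on a few compounds, and the source may have more. Where it says the series, first, only, none or still open, it means among the compounds named here.

Measured so far in an ADME assay on microsomes from liver (Rattus norvegicus) for metabolic stability, read by LC-MS, using NADPH, with a stated time of 10 min, tested at 0.1 uM; a lower number here means slower removal, a higher number faster removal of the compound:

compound 1, `Cc1cccc(N2C(=O)CSC2c2cccc(C(=O)NCCCCc3ccccc3)c2)c1`, gives 3140 mL.min-1.g-1
compound 2, `Cc1ccnc(N2C(=O)CSC2c2cccc(C(=O)NCCCCn3cccn3)c2)c1`, gives 1020 mL.min-1.g-1
compound 3, `O=C(NCCCCc1ccccc1)c1cccc(C2SCC(=O)N2c2cccc(F)c2)c1`, gives 3240 mL.min-1.g-1

Compound 2 stands lowest of the three in this assay, and its gaps to compound 1 and to compound 3 are both beyond the scatter. How the core of compound 2 differs from the core of compound 1 is not broken down here; the two differ in more than one place.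

Compound 1 and compound 3 share a core and differ only in that (fluoro in place of methyl on an aromatic carbon). That step reads a 1.0-fold higher number from compound 1 to compound 3 (0.01 log units; within the scatter), so the two values are treated as the same.

Compound 4, `O=C(NCCCCn1cccn1)c1cccc(C2SCC(=O)N2c2cc(F)ccn2)c1`, is not yet measured. Against compound 2 it carries fluoro in place of methyl on an aromatic carbon. For the measured compounds named here, this is the same kind of change as the one from compound 1 to compound 3, not the same one: here the aromatic carbon lies in a six-membered aromatic ring with 1 nitrogen, meta to a large group and opposite the ring nitrogen, whereas in compound 1 and compound 3 it lies in a six-membered aromatic ring of carbon only, meta to a large group.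

The step from compound 2 to compound 4 in this assay is expected to be a 1.0-fold higher number from compound 2 to compound 4 (0.01 log units; within the scatter), resting on the flat step a 1.0-fold higher number from compound 1 to compound 3 (0.01 log units; within the scatter) and on the value of compound 2, 1020 mL.min-1.g-1. Compound 4 is therefore estimated at 1050 mL.min-1.g-1, with a likely span from 500 mL.min-1.g-1 to 2200 mL.min-1.g-1. This rests on a single pair and on a ring that is not the same, so the expectation is loosely held.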

Compound 4, intrinsic clearance in microsomes in the Rattus norvegicus assay: 1200 mL.min-1.g-1
For compound 4 the middle estimate is 1.1-fold (0.06 log units) below the measured one; the range from low to high includes it.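

In the Rattus norvegicus assay compound 2 gives 1020 mL.min-1.g-1 and compound 4 gives 1200 mL.min-1.g-1. In the Rattus norvegicus assay the exchange of methyl for fluoro gives a 1.2-fold higher number from compound 2 to compound 4 (0.07 log units; within the scatter), and the step agrees with the one seen earlier on the other core: the same change on two cores in the Rattus norvegicus assay, a 1.0-fold higher number (0.01 log units; within the scatter) from compound 1 to compound 3 and a 1.2-fold higher number (0.07 log units; within the scatter) from compound 2 to compound 4, 1.1-fold (0.06 log units) apart, within the scatter of two such steps. On these two cores the exchange therefore carries across unchanged within the scatter, whether the aromatic carbon lies in a ring of carbon only or in a six-membered aromatic ring with 1 nitrogen, and in a physicochemical assay for solubility, read by turbidimetry, measured as kinetic solubility, at pH 6.8 (on this read-out lower numbers stand for lower solubility and higher numbers for higher solubility), the newer pair shows no change at the digits printed from compound 2 to compound 4 (within the scatter). In the physicochemical assay compound 2 gives 50000 nM and compound 4 gives 50000 nM. For the compounds shown here, this rests on only two pairs, both flat, so it does not show that the same result would hold on a further core, that a step of real size would transfer in the same way, or why neither step departs from the scatter.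

The compounds shown leave open whether another group at the same place, such as chloro, methoxy or an amine, would move the number in the Rattus norvegicus assay beyond the scatter on either core. They also leave open whether the flat result of the exchange would persist with a longer chain on the amide.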